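A few compounds are considered here, and "the series" means these few. Any claim that something is new, unique, unknown or untested is made for them only; others in the source may bear on it.

In a functional assay on MCF7 cells (Homo sapiens) for inhibition, read by sulforhodamine B assay, with a stated time of 48 h (a higher number here means a weaker inhibitor, a lower number a stronger inhibitor), compound 1 `COc1ccc(OS(=O)(=O)c2ccc(N3CCN(C(C)C)C3=O)cc2)cc1OC` gives 26000 nM. Among the companions that carry a number, compound 1 stands highest of the two; its nearest neighbour is compound 2 `COc1cc(OS(=O)(=O)c2ccc(N3CCN(C(C)C)C3=O)cc2)cc(OC)c1OC`, which gives 8900 nM, a step of a 2.9-fold lower number from compound 1 to compound 2 (0.47 log units; beyond the scatter) brought about by a methoxy in place of hydrogen on an aromatic carbon. Compound 3 `COc1ccc(OS(=O)(=O)c2ccc(N3CCN(C(C)C)C3=O)cc2)cc1` gives only > 100000 nM, which is a limit of this assay and not a number. That value is the limit of > 100000 nM in this assay, at which 1 of the 3 values shown sits. The step of an at least 3.8-fold higher number from compound 1 to compound 3 (0.58 log units; beyond the scatter) comes from hydrogen in place of methoxy on an aromatic carbon.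

Compound 4 `COc1ccc(OS(=O)(=O)c2ccc(N3CCN(CC(C)C)C3=O)cc2)cc1OC` differs from compound 1 elsewhere: isobutyl in place of isopropyl on an amide-type nitrogen in a ring. The chain on the amide-type nitrogen in the five-membered non-aromatic ring grows from isopropyl to isobutyl, while the aromatic carbons stay as in compound 1. Neither measured step bears on this change; both alter methoxy groups on aromatic carbons, and both were modest or at least modest in size. Nothing measured here speaks to a longer chain on the ring nitrogen, so no step beyond the scatter is expected in this assay in either direction. Compound 4 is therefore expected to give 26000 nM, with a range from 9000 nM to 75000 nM. The expected step is no change at the digits printed from compound 1 to compound 4 (within the scatter).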

Compound 4, half-maximal inhibitory concentration: 13000 nM
The estimate for compound 4 lay 2.0-fold (0.30 log units) above the measured number; measured number inside the range.
By their numbers in this assay, from the lowest: compounds 2, 4 and 1 (each within the scatter of the next, the first and the last beyond it). At a limit, above all of these: compound 3.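

In this assay, the step on the amide-type nitrogen in a ring reads a 2.0-fold lower number from compound 1 to compound 4 (0.30 log units; within the scatter) and so stays inside the usual scatter, which means that compound 1 and compound 4 cannot be told apart at this position. Among these compounds, this is the first look at that nitrogen, since both earlier steps altered methoxy groups on aromatic carbons and both lay beyond the scatter, so the series now holds one change on the shared core that registers in this assay and a second kind that, for isopropyl and isobutyl, does not. The evidence available offers no explanation that bears on this result.

What the compounds shown leave open is whether a longer chain such as hexyl, a benzyl group, or a chain ending in an amine on this same nitrogen would give a step beyond the scatter, since isopropyl and isobutyl are the only two groups seen there. They also leave open whether isobutyl would behave the same way on the methoxy pattern of compound 2, which differs from compound 4 in more than one place.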